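From aminomethyl to 4-aminophenyl on the shared core

The source may report more compounds than this note shows. Statements on the series, on what has been measured and on what is new or still open speak of the compounds shown alone.

Values so far in an ADME assay on cells (spleen, Mus musculus, strain C57BL/6) for inhibition, read by flow cytometry and propidium iodide staining, with a stated time of 24 h, at 37 degrees C; a lower number here means that less compound is needed, a higher number that more compound is needed for the effect:
- Compound 1 `O=C(Cn1cc(CO)nn1)NCc1ccccc1` gives 490 uM as a number
- Compound 2 `O=C(O)CCc1cn(CC(=O)NCc2ccccc2)nn1` gives 1420 uM as a number
- Compound 3 `NCc1cn(CC(=O)NCc2ccccc2)nn1` gives > 2000 uM as a limit

Compound 3 stands at the limit of > 2000 uM in this assay, at which 1 of the 3 values shown sits, and has no exact number. Compound 4 `Nc1ccc(-c2cn(CC(=O)NCc3ccccc3)nn2)cc1` carries 4-aminophenyl in place of aminomethyl on an aromatic carbon, with 4-aminophenyl in place of aminomethyl on an aromatic carbon as the counted change. Measured steps at this place are a 2.9-fold higher number from compound 1 to compound 2 (0.46 log units; beyond the scatter), an at least 4.0-fold higher number from compound 1 to compound 3 (0.61 log units; beyond the scatter) and an at least 1.4-fold higher number from compound 2 to compound 3 (0.14 log units; that floor lies within the scatter). None of them brings in an aromatic ring, so they fix no size for this change. A lower number is expected, because compound 1 at 490 uM shows that a measurable number is possible with a change at this place. The expected move is an at least 4.0-fold lower number from compound 3 to compound 4 (0.60 log units; beyond the scatter) as an estimate. Compound 4 is estimated at 500 uM, with an expected range from 120 uM to 1800 uM.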

Compound 4, concentration for half-maximal effect: 1240 uM
The estimate for compound 4 lay 2.5-fold (0.39 log units) below the measured number; measured number inside the range.
By their numbers in this assay, from the lowest: compound 1; then compounds 4 and 2 (each within the scatter of the next). At a limit, above all of these: compound 3.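

With an aromatic ring at this place the number becomes measurable, while compound 3 has only a limit: the limit of > 2000 uM in this assay, at which 1 of the 4 values shown sits. The step reads only as a floor, an at least 1.6-fold lower number from compound 3 to compound 4 (0.20 log units; that floor lies within the scatter), and its true size cannot be read. Against 2-carboxyethyl, 4-aminophenyl gives a 1.1-fold lower number from compound 2 to compound 4 (0.06 log units; within the scatter), and against hydroxymethyl it gives a 2.5-fold higher number from compound 1 to compound 4 (0.40 log units; beyond the scatter), so the aromatic ring does not reach the number of compound 1.

The compounds shown leave open what the amine on that ring contributes compared with a plain phenyl. They also leave open how a hydroxymethyl or a carboxylic acid on that ring would read.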